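A few compounds are considered here, and "the series" means these few. Any claim that something is new, unique, unknown or untested is made for them only; others in the source may bear on it.

Compound 1 `O=C1CCC(=O)N1C[C@H]1CN(c2ccc(-n3cc(-c4ccccn4)cn3)c(F)c2)C(=O)O1` gives 1.58 in a physicochemical assay for lipophilicity, read by HPLC, measured as octanol-water partition; on this read-out higher numbers stand for higher lipophilicity and lower numbers for lower lipophilicity.
Compound 2 `CC(=O)OC[C@H]1CN(c2ccc(-n3cc(-c4ccccn4)cn3)c(F)c2)C(=O)O1` gives 2.09 in this assay.

Among the compounds with values here, compound 2 holds the higher of the two measured numbers; its only neighbour, compound 1, lies beyond the scatter below it, as the step of a number 0.51 log units higher from compound 1 to compound 2 (beyond the scatter) shows, where acetoxy replaced 2,5-dioxopyrrolidin-1-yl on a saturated chain carbon bound to a saturated ring carbon.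

Compound 3 `CN(C)S(=O)(=O)NC[C@H]1CN(c2ccc(-n3cc(-c4ccccn4)cn3)c(F)c2)C(=O)O1` has not been measured yet. It keeps the shared core and changes compound 2 at the same place: (dimethylsulfamoyl)amino in place of acetoxy on a saturated chain carbon bound to a saturated ring carbon.

Within the data shown here, the one measured step bears on this only loosely: it shows that swapping the group on this saturated chain carbon can move the read-out by a modest amount. Among the measured compounds shown here, no step shows what a (dimethylsulfamoyl)amino group does here. The entering group brings a hydrogen-bond donor that acetoxy lacks, so a decrease is expected rather than an increase. For compound 3 the expected step is a number 0.39 log units lower from compound 2 to compound 3 (beyond the scatter). The estimate for compound 3 is therefore 1.7, within a range from 1.2 to 2.2.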

Compound 3, partition coefficient: 1.38
Compound 3: the middle estimate sits 0.32 log units above what was measured, and the stated range covers the measured number.
By their numbers in this assay, from the lowest: compounds 3 and 1 (each within the scatter of the next); then compound 2.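

In this assay, a third group on this saturated chain carbon now allows a comparison among three groups, and acetoxy stands apart from (dimethylsulfamoyl)amino (a number 0.71 log units lower from compound 2 to compound 3 (beyond the scatter)), as it already did from 2,5-dioxopyrrolidin-1-yl (a number 0.51 log units higher from compound 1 to compound 2 (beyond the scatter)). The two groups attached through nitrogen cannot be told apart on this read-out (a number 0.20 log units lower from compound 1 to compound 3 (within the scatter)), even though 2,5-dioxopyrrolidin-1-yl is a ring and (dimethylsulfamoyl)amino has no ring, so among these three compounds, with none going against it, only compound 2, with its group attached through oxygen, stands apart. This is a description of three numbers, and nothing measured here explains why they fall this way.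

Three groups cannot show whether the attaching atom matters at all, and an acetamido group at the same place, which keeps the acetyl part of acetoxy but attaches through nitrogen, would separate that question from the rest of the group. On these data alone, it also remains open where a plain amine or a carboxylic acid on this carbon would fall relative to these three compounds.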